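Demethylating the Methoxy Group of Compound 2

The compounds below may be only part of what the source reports. "The series", "measured", "known", "first", "only" and "open" are said of these compounds alone.

Three compounds have been measured so far:
- compound 1, `COc1cc(-c2nn(-c3cccc(NC(=O)c4ccc(Cl)c(C(F)(F)F)c4)c3)cc2-c2ccncc2)ccc1Cl`: > 32500 nM
- compound 2, `COc1cc(-c2nn(-c3cccc(NC(=O)Nc4ccc(Cl)c(C(F)(F)F)c4)c3)cc2-c2ccncc2)ccc1Cl`: 16700 nM
- compound 3, `COc1cc(-c2nn(-c3cccc(NC(=O)c4ccccc4)c3)cc2-c2ccncc2)ccc1Cl`: > 100000 nM

All three were tested in a functional assay on A549 cells (Homo sapiens) for inhibition, read by sulforhodamine B assay, with a stated time of 48 h; a higher number here means a weaker inhibitor of growth, a lower number a stronger inhibitor of growth. Compound 2 is the only one of the three that gives an actual number, 16700 nM. For compound 1 the result is a limit of the assay, > 32500 nM, not a number. For compound 3 the result is likewise a limit, > 100000 nM. Among the shown values, compound 2 therefore stands alone as a measured point, with the other two sitting at limits the limit of > 32500 nM in this assay, at which 1 of the 3 values shown sits, and (the limit of > 100000 nM in this assay, at which 1 of the 3 values shown sits).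

The measured steps all alter the group on the carbonyl carbon: an at least 1.9-fold lower number from compound 1 to compound 2 (0.28 log units; that floor lies within the scatter), an at least 5.9-fold higher number from compound 2 to compound 3 (0.77 log units; beyond the scatter), and between compound 1 and compound 3 the two limits leave the size unreadable.

Compound 4, `O=C(Nc1cccc(-n2cc(-c3ccncc3)c(-c3ccc(Cl)c(O)c3)n2)c1)Nc1ccc(Cl)c(C(F)(F)F)c1`, changes a different part of the molecule: hydrogen in place of methyl on an oxygen on an aromatic ring. None of the measured steps touches this oxygen, so no step shown here bears directly on it. With the amide replaced by a urea as in compound 2 kept intact, the expectation is a change of about a 1.1-fold lower number from compound 2 to compound 4 (0.05 log units; within the scatter), which is not beyond the scatter. Compound 4 is therefore estimated at 15000 nM, within a range from 5000 nM to 45000 nM.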

Compound 4, concentration for total growth inhibition: 5090 nM
Compound 4: the middle estimate sits 2.9-fold (0.47 log units) above what was measured; measured number inside the range.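

In this assay, replacing methoxy with hydroxy on the 4-chloro-3-methoxyphenyl group, with the urea kept in place, gives a 3.3-fold lower number from compound 2 to compound 4 (0.52 log units; beyond the scatter). The earlier steps shown here all changed the group on the carbonyl carbon, so they could say nothing about this oxygen; this step shows that growth inhibition also responds to what sits on it, and that losing a methyl, a single carbon, is enough to move the result beyond the scatter. The data shown here offer no explanation for this shift, and the two assay limits recorded for other compounds do not bear on it.

On these data alone, with only methyl and hydrogen compared on this oxygen, it remains open whether an ethyl group or a longer chain there would weaken growth inhibition or whether an amine in place of the hydroxy would match it. It is also open whether the same swap from methoxy to hydroxy would help in the amide series, since the step shown here comes from the urea compounds alone.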